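The source may report more compounds than this note shows. Statements on the series, on what has been measured and on what is new or still open speak of the compounds shown alone.

Working notes on the series. Compound 2 `Cc1nc2ccccc2c(=O)n1/N=C/c1ccc(Oc2ccc([N+](=O)[O-])cc2)cc1` is the reference point; in a physicochemical assay for lipophilicity, in phosphate buffer, measured as octanol-water partition (on this read-out lower numbers stand for lower lipophilicity and higher numbers for higher lipophilicity), compound 2 gives 4.01. Compound 1 `O=c1c2ccccc2nc(-c2ccccc2)n1/N=C/c1ccc(Oc2ccc([N+](=O)[O-])cc2)cc1` carries phenyl in place of methyl on an aromatic carbon and in this assay compound 1 gives 6.12, a step of a number 2.11 log units higher from compound 2 to compound 1 (beyond the scatter). Compound 3 `Cc1cc(Oc2ccc(/C=N/n3c(C)nc4ccccc4c3=O)cc2)ccc1Cl` differs from compound 2 in the cores by 4-chloro-3-methylphenyl in place of 4-nitrophenyl on an oxygen on an aromatic ring; in this assay compound 3 gives 4.41, a step of a number 0.40 log units higher from compound 2 to compound 3 (beyond the scatter).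

Compound 4 `Cc1cc(Oc2ccc(/C=N/n3c(-c4ccccc4)nc4ccccc4c3=O)cc2)ccc1Cl` is not yet measured. It differs from compound 3 by phenyl in place of methyl on an aromatic carbon, the same change that separates compound 2 from compound 1, at a place described in identical words in both pairs. The step from compound 3 to compound 4 is therefore expected to be about a number 1.99 log units higher from compound 3 to compound 4 (beyond the scatter), resting on the step of a number 2.11 log units higher from compound 2 to compound 1 (beyond the scatter). Compound 4 is estimated at 6.4, within 5.7 to 7.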

Compound 4, partition coefficient: 6.52
Estimate against measurement, compound 4: 0.12 log units below; measured number inside the range.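

In this assay phenyl in place of methyl on an aromatic carbon gives a number 2.11 log units higher from compound 3 to compound 4 (beyond the scatter) and also a number 2.11 log units higher from compound 2 to compound 1 (beyond the scatter) on the other core, so the change carries over at full size. The two changes also add up in these four compounds: with phenyl present, a number 0.40 log units higher from compound 1 to compound 4 (beyond the scatter) stands against a number 0.40 log units higher from compound 2 to compound 3 (beyond the scatter) with methyl present. This is a single pair of cores, so it sets no general rule, and nothing available says why the step keeps its size.

On these data alone, whether the step holds on a core carrying an amine or a carboxylic acid in place of 4-chloro-3-methylphenyl stays open. So does the effect of an ethyl or propyl chain in place of methyl.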